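From isopropylamino to cyclohexylamino: compound 4 in prospect

The source may report more compounds than this note shows. Statements on the series, on what has been measured and on what is new or still open speak of the compounds shown alone.

Measured so far in an ADME assay on Akata cells (Homo sapiens) for cytotoxicity, with a stated time of 7 days; a higher number here means that more compound is tolerated, a lower number that less compound is tolerated:
- compound 1 (`CNc1nc(N)nc2c1ncn2/C=C1/CC1(CO)CO`) gives > 24000 nM as a limit
- compound 2 (`CC(C)CSc1nc(N)nc2c1ncn2/C=C1/CC1(CO)CO`) gives > 20000 nM as a limit
- compound 3 (`CC(C)Nc1nc(N)nc2c1ncn2/C=C1/CC1(CO)CO`) gives > 24000 nM as a limit

Compound 3 has only the limit > 24000 nM to show, not a true number. The other two compounds are in the same position, so none of the three can be ranked. All the values fall on two limits: the limit of > 24000 nM in this assay, at which 2 of the 3 values shown sit, and the limit of > 20000 nM in this assay, at which 1 of the 3 values shown sits, in the second case.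

Compound 4 (`Nc1nc(NC2CCCCC2)c2ncn(/C=C3/CC3(CO)CO)c2n1`) has cyclohexyl in place of isopropyl on a nitrogen on an aromatic ring. The closest measured change is isopropyl in place of methyl on that nitrogen, which is a step that the two limits leave unreadable from compound 1 to compound 3 and so gives no usable size. The changes on the aromatic carbon, a step that the two limits leave unreadable from compound 1 to compound 2 and a step that the two limits leave unreadable from compound 2 to compound 3 as well, add no size either. With only these steps to go on, no shift beyond the usual scatter is expected in this assay. The expected change is an at least 1.2-fold lower number from compound 3 to compound 4 (0.07 log units; that floor lies within the scatter) and it rests on limits alone. For compound 4 the estimate is 20000 nM with an expected range from 7000 nM to 40000 nM and a good chance of another limit.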

Compound 4, half-maximal cytotoxic concentration: > 24000 nM
Compound 4: only a limit was reported (the forecaster's own chance of this, stated with the estimate: 65%); at least 1.2-fold (0.07 log units) between middle value and limit.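

In this assay compound 4 gives > 24000 nM, which is a limit and not a true number. Compound 1, compound 2 and compound 3 also have only limits, so none of their steps to compound 4 can be read. Still open, as far as these compounds go, is whether methylamino, isobutylsulfanyl, isopropylamino and cyclohexylamino differ at all in this assay.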